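The source may hold more compounds than are shown below. What is called first, only, known or untested is meant among the compounds shown, and "the series" means these compounds.

Measured so far in a functional assay on A549 cells (Homo sapiens) for cytotoxicity, with a stated time of 48 h; a higher number here means a weaker inhibitor, a lower number a stronger inhibitor:
Compound 1 `CCOc1ccc2oc(/C=C/[S+](C)[O-])cc(=O)c2c1`: 1500 nM
Compound 2 `CC(C)COc1ccc2oc(/C=C/[S+](C)[O-])cc(=O)c2c1`: 1100 nM
Compound 3 `C[S+]([O-])/C=C/c1cc(=O)c2ccccc2o1`: 1900 nM

On these numbers, compound 3 cannot be separated from the other two compounds. Compound 4 `Cc1cccc2oc(/C=C/[S+](C)[O-])cc(=O)c12` is compound 3 with methyl in place of hydrogen on an aromatic carbon. The closest measured changes also exchange hydrogen and a group on an aromatic carbon: a 1.3-fold higher number from compound 1 to compound 3 (0.10 log units; within the scatter) and a 1.7-fold higher number from compound 2 to compound 3 (0.24 log units; within the scatter). For the measured compounds named here, both stay within the scatter, but they involve ethoxy and isobutoxy, and no measured compound shows what methyl does at this place. The expected step is therefore small and not beyond the scatter: a 1.2-fold lower number from compound 3 to compound 4 (0.07 log units; within the scatter). Compound 4 is estimated at 1600 nM, with an expected range of 800 nM to 3200 nM.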

Compound 4, half-maximal inhibitory concentration: 1300 nM
Compound 4: middle estimate off by 1.2-fold (0.09 log units), on the high side, and the stated range covers the measured number.
By their numbers in this assay, from the lowest: compounds 2, 4, 1 and 3 (each within the scatter of the next).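

On the aromatic carbon ortho to a fused ring, methyl in place of hydrogen gives a 1.5-fold lower number from compound 3 to compound 4 (0.16 log units; within the scatter) in this assay. For the compounds shown here, this is the first look at this carbon, since the ethoxy and isobutoxy groups of the earlier compounds sit elsewhere on the shared core, and a methyl here leaves the number within the scatter. No measured evidence bears on why this step is so small. On these data alone, whether an amine, a carboxylic acid or a longer chain on this same carbon would move the number beyond the scatter remains open.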